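Clearance notes on a sulfonamide ether amide series

The source may hold more compounds than are shown below. What is called first, only, known or untested is meant among the compounds shown, and "the series" means these compounds.

Of the compounds shown here, three of one series have been measured in an in vivo ADME assay on the whole organism (strain Sprague-Dawley) for pharmacokinetics, with Rattus norvegicus as the target; a lower number here means slower removal, a higher number faster removal of the compound. Compound 1 `COc1cc(C)c(S(=O)(=O)N(C)CCOCC(=O)N2CCC(C(C)(C)CN(C)C)CC2)c(C)c1` gives 19.2 mL/min/kg. Compound 2 `COc1cc(C)c(S(=O)(=O)N(C)CCOCC(=O)N(C)Cc2ccc(C3=NCCN3)cc2)c(C)c1` gives 27.4 mL/min/kg, and compound 3 `COc1cc(C)c(S(=O)(=O)N(C)CCOCC(=O)N2CCN(CC3CCN(C)CC3)CC2)c(C)c1` gives 32.5 mL/min/kg. Compound 1 holds the lowest number of the three, but its gaps to compound 2 and to compound 3 both lie within the usual scatter, so no order among the three can be read from these numbers. Compound 4 `COc1cc(C)c(S(=O)(=O)N(C)CCOCC(=O)N2CCC(C3CCN(C)CC3)CC2)c(C)c1` is not yet measured. It differs from compound 1 in one place: 1-methylpiperidin-4-yl in place of 1-((dimethylamino)methyl)-1-methylethyl on a saturated ring carbon. Going by the values given here, no step between measured compounds is available for comparison, so only a small step is expected here, within the scatter, in either direction. Compound 4 is expected to give 24 mL/min/kg in this assay, within a range from 12 mL/min/kg to 48 mL/min/kg. The expected step is a 1.3-fold higher number from compound 1 to compound 4 (0.10 log units; within the scatter).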

Compound 4, clearance: 17.9 mL/min/kg
Compound 4: middle estimate off by 1.3-fold (0.13 log units), on the high side, and the stated range covers the measured number.
By their numbers in this assay, from the lowest: compounds 4, 1, 2 and 3 (each within the scatter of the next).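

In this assay, going by these compounds alone, 1-methylpiperidin-4-yl in place of 1-((dimethylamino)methyl)-1-methylethyl on a saturated ring carbon gives a 1.1-fold lower number from compound 1 to compound 4 (0.03 log units; within the scatter) and is the first single-place comparison. At this position, an open-chain group and a ring-bearing group, each with one nitrogen, thus give clearance values that cannot be told apart. No measurement at hand bears on the reason for this result. From the compounds shown here alone, whether a cyclohexyl group or a carboxylic acid at this ring carbon would shift clearance beyond the scatter remains open.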